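Amine substituent on the shared core: methylamino to ethylamino

A few compounds are considered here, and "the series" means these few. Any claim that something is new, unique, unknown or untested is made for them only; others in the source may bear on it.

compound 1 `CCCCN(CCCC)c1nc2c(ncn2-c2ccccc2)c(=O)n1-c1ccccc1` — 10000 nM
compound 2 `CC(C)N(c1nc2c(ncn2-c2ccccc2)c(=O)n1-c1ccccc1)C(C)C` — a limit of the assay, > 100000 nM
compound 3 `CNc1nc2c(ncn2-c2ccccc2)c(=O)n1-c1ccccc1` — a limit of the assay, > 100000 nM

In a functional assay on OVCAR-3 cells (Homo sapiens) for cytotoxicity, read by MTT assay, with a stated time of 72 h (a higher number here means a weaker inhibitor, a lower number a stronger inhibitor), compound 1 gives 10000 nM. For compound 2 the value is a limit of the assay, > 100000 nM. For compound 3 the value is likewise a limit, > 100000 nM, which is the limit of > 100000 nM in this assay, at which 2 of the 3 values shown sit. Compound 4 `CCNc1nc2c(ncn2-c2ccccc2)c(=O)n1-c1ccccc1` differs from compound 3 by methyl in place of hydrogen on a saturated chain carbon bound to a nitrogen on an aromatic ring. The measured steps at this site are an at least 10-fold higher number from compound 1 to compound 2 (1.00 log units; beyond the scatter) and an at least 10-fold higher number from compound 1 to compound 3 (1.00 log units; beyond the scatter); a step that the two limits leave unreadable from compound 2 to compound 3. None of these reads a change from methylamino to ethylamino, and both smaller amines sit at the limit. Compound 4 is therefore expected to stay near that limit, with a number no higher from compound 3 to compound 4 (the limit leaves the size open) as the expected step. The estimate for compound 4 is 100000 nM, between 30000 nM and 300000 nM.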

Compound 4, half-maximal inhibitory concentration: > 100000 nM
Compound 4 ended at the assay's limit; the forecaster's own chance of this, stated with the estimate: 65%; the middle value sits exactly at the limit.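

In this assay, methyl in place of hydrogen on a saturated chain carbon bound to a nitrogen on an aromatic ring gives no measurable gain, and the ethylamino compound 4 joins the other small amines at the limit: the limit of > 100000 nM in this assay, at which 3 of the 4 values shown sit.

Among the amines shown, dibutylamino alone gives a readable value, with an at least 10-fold higher number from compound 1 to compound 4 (1.00 log units; beyond the scatter). The steps among compound 2, compound 3 and compound 4 cannot be read.

From the compounds shown here alone, what remains open is whether a butylamino or dipropylamino group would give a readable value, and so whether chain length or the presence of two chains matters more.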